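Shifting the Amine: Estimating a Fourth Analogue's Cytotoxicity

The source may hold more compounds than are shown below. What is called first, only, known or untested is meant among the compounds shown, and "the series" means these compounds.

Three analogues sharing one core were compared in a functional assay on MCF7 cells (Homo sapiens) for cytotoxicity, read by MTT assay, with a stated time of 96 h; a higher number here means a weaker inhibitor, a lower number a stronger inhibitor. Compound 1 `COc1cc(C(=O)c2cn(-c3cccc(C)c3)cc2-c2cccc(N)c2)cc(OC)c1OC` gives 130 nM. Compound 2 `COc1cc(C(=O)c2cn(-c3cccc(C)c3)cc2-c2ccc(N)cc2)cc(OC)c1OC` gives 18 nM; the change between them, (4-aminophenyl in place of 3-aminophenyl on an aromatic carbon), produced a 7.2-fold lower number from compound 1 to compound 2 (0.86 log units; beyond the scatter). Compound 3 `COc1cc(C(=O)c2cn(-c3ccc(F)cc3)cc2-c2cccc(N)c2)cc(OC)c1OC` gives 53 nM; it differs from compound 1 by 4-fluorophenyl in place of 3-methylphenyl on an aromatic nitrogen, which produced a 2.5-fold lower number from compound 1 to compound 3 (0.39 log units; beyond the scatter). Among the compounds with values here, for compound 2 and compound 3 no step is counted here; their two values alone show compound 2 with the lower number.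

Compound 4 `COc1cc(C(=O)c2cn(-c3ccc(F)cc3)cc2-c2ccc(N)cc2)cc(OC)c1OC` has not yet been measured in this assay. It differs from compound 3 by 4-aminophenyl in place of 3-aminophenyl on an aromatic carbon. This is the same kind of change as that from compound 1 to compound 2, though around the place the ring atom two ring bonds away bears a 4-fluorophenyl group rather than a 3-methylphenyl group. With a single earlier example, the expectation rests on the step from compound 1 to compound 2, a 7.2-fold lower number from compound 1 to compound 2 (0.86 log units; beyond the scatter), applied to compound 3 at 53 nM. Compound 4 is therefore expected to show a 6.6-fold lower number from compound 3 to compound 4 (0.82 log units; beyond the scatter) in this assay, close to the earlier step. Compound 4 is estimated at 8 nM, expected to fall between 3 nM and 20 nM.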

Compound 4, half-maximal inhibitory concentration: 12 nM
Beside the measured number, compound 4's estimate is 1.5-fold (0.18 log units) below it, and the stated range covers the measured number.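

In this assay, 4-aminophenyl in place of 3-aminophenyl gave a 4.4-fold lower number from compound 3 to compound 4 (0.65 log units; beyond the scatter), so the change kept its direction and held its size on the core bearing 4-fluorophenyl: the same change on two cores in this assay, a 7.2-fold lower number (0.86 log units; beyond the scatter) from compound 1 to compound 2 and a 4.4-fold lower number (0.65 log units; beyond the scatter) from compound 3 to compound 4, 1.6-fold (0.21 log units) apart, within the scatter of two such steps. The other change, 4-fluorophenyl in place of 3-methylphenyl, gave a 1.5-fold lower number from compound 2 to compound 4 (0.18 log units; within the scatter) on the core bearing 4-aminophenyl, a step within the scatter on its own, yet not set apart from its earlier counterpart: the same change on two cores in this assay, a 2.5-fold lower number (0.39 log units; beyond the scatter) from compound 1 to compound 3 and a 1.5-fold lower number (0.18 log units; within the scatter) from compound 2 to compound 4, 1.6-fold (0.21 log units) apart, within the scatter of two such steps. These four compounds show that, for this one pair of groups on the ring nitrogen, the two changes can be carried across without a gap beyond the scatter, but they do not show that this would hold on any other core, nor why the amine's position matters.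

The compounds shown leave open whether a hydroxyl or a dimethylamino group in place of the amine would respond in the same way. They also leave open how a chlorophenyl or an unsubstituted phenyl group on the ring nitrogen would fit the pattern.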